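A few compounds are considered here, and "the series" means these few. Any claim that something is new, unique, unknown or untested is made for them only; others in the source may bear on it.

Working notes on the series. In a functional assay on FaDu cells (Homo sapiens) for cytotoxicity, read by MTT assay, with a stated time of 72 h (a lower number here means that less compound is tolerated, a higher number that more compound is tolerated), compound 1 `CCOc1ccc(NC(=O)C(=O)c2cn(C(C)C)c3ccccc23)cn1` gives 175 nM and compound 2 `COc1ccc(NC(=O)C(=O)c2cn(C(C)C)c3ccccc23)cn1` gives 85 nM. Compound 3 `COc1ccc2c(C(=O)C(=O)Nc3ccc(OC)nc3)cn(C(C)C)c2c1` stands at > 10000 nM, which is a limit of the assay and not a number.

Compound 4 `COc1ccc(NC(=O)C(=O)c2cn(C(C)C)c3cc(Cl)ccc23)cn1` differs from compound 3 by chloro in place of methoxy on an aromatic carbon, part of a fused system of two rings: chloro in place of methoxy on an aromatic carbon.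

Two measured steps are available. The first, a 2.1-fold lower number from compound 1 to compound 2 (0.31 log units; beyond the scatter), is modest and concerns the chain on the oxygen, away from the carbon that changes here, so it bears on this change only weakly. The second, an at least 110-fold higher number from compound 2 to compound 3 (2.07 log units; beyond the scatter), is large and bears directly, since it introduces methoxy on the same aromatic carbon that carries chloro in compound 4.

Going by the values given here, no measured compound has chloro on this carbon, so the size of the step is uncertain. Replacing methoxy is expected to recover part of the loss seen in an at least 110-fold higher number from compound 2 to compound 3 (2.07 log units; beyond the scatter), but not all of it, since that carbon still carries a group other than hydrogen. The expected move is toward a lower number in this assay, and the estimated step is an at least 11-fold lower number from compound 3 to compound 4 (1.04 log units; beyond the scatter). For compound 4 the estimate is 900 nM, with an expected range of 120 nM to 8000 nM.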

Compound 4, concentration lethal to 50% of the cells: 1770 nM
Compound 4: middle estimate off by 2.0-fold (0.29 log units), on the low side; the measured number falls inside the stated range.
By their numbers in this assay, from the lowest: compound 2; then compound 1; then compound 4. At a limit, above all of these: compound 3.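

In this assay, the aromatic carbon that carries methoxy in compound 3 gives a measurable number once chloro stands there, with an at least 5.6-fold lower number from compound 3 to compound 4 (0.75 log units; beyond the scatter), so the result at this carbon depends on which group it carries and not merely on whether it carries a group other than hydrogen. Hydrogen on the same carbon still gives the lower number, with a 21-fold higher number from compound 2 to compound 4 (1.32 log units; beyond the scatter), so among the compounds shown, chloro does not bring the series back to the level of compound 2. Compound 3 stands at a limit of the assay and not at a number, so the step from methoxy to chloro gives only a lower bound on its size: the limit of > 10000 nM in this assay, at which 1 of the 4 values shown sits.

As far as these compounds go, with only hydrogen, chloro and methoxy compared on this carbon, it remains open where a fluoro, a methyl, a nitrile or an amine would fall. Also open, from the compounds shown here alone, are how chloro behaves on the other carbons of this six-membered aromatic ring, and whether a longer chain on the oxygen of the other ring shifts the number in the same way when chloro is present.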